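The compounds below may be only part of what the source reports. "The series", "measured", "known", "first", "only" and "open" are said of these compounds alone.

For the measured compounds named here, only two compounds sharing this core have been measured so far in a functional assay on HCT-116 cells (Homo sapiens) for antiproliferative activity, with a stated time of 4 h; on this read-out higher numbers stand for weaker inhibition and lower numbers for stronger inhibition. Compound 1 `O=c1ccc(=O)c2c1c1[nH]c3ccccc3c1c1c(=O)[nH]c(=O)c21` gives 5300 nM. Methyl in place of hydrogen on an aromatic carbon leads to compound 2 `Cc1ccc2[nH]c3c4c(=O)ccc(=O)c4c4c(=O)[nH]c(=O)c4c3c2c1`, which gives 700 nM, the lower of the two numbers and so the stronger inhibition.

The next compound is compound 3 `O=c1ccc(=O)c2c1c1[nH]c3ccc(O)cc3c1c1c(=O)[nH]c(=O)c21`, which has hydroxy in place of methyl on an aromatic carbon. Going by the values given here, one measured step bears on this change, a 7.6-fold lower number from compound 1 to compound 2 (0.88 log units; beyond the scatter), a modest but real gain on swapping hydrogen for methyl. Among the compounds with values here, no compound with hydroxy has been measured yet, so that single step is only a rough guide to the size of the change. The methyl is lost here, and hydroxy is expected to keep only part of the gain seen with methyl.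

The expected result is a small move toward weaker inhibition, a 2.3-fold higher number from compound 2 to compound 3 (0.36 log units; beyond the scatter). For compound 3, the estimate is 1600 nM, with an expected range from 400 nM to 6000 nM.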

Compound 3, half-maximal inhibitory concentration: 15400 nM
Beside the measured number, compound 3's estimate is 9.6-fold (0.98 log units) below it; the whole stated range lies below it.
By their numbers in this assay, from the lowest: compound 2; then compound 1; then compound 3.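

At this position, on a six-membered aromatic ring of carbon only, the choice of group has a much larger effect than the first step suggested: a 22-fold higher number from compound 2 to compound 3 (1.34 log units; beyond the scatter) is a large step in this assay and exceeds the modest 7.6-fold lower number from compound 1 to compound 2 (0.88 log units; beyond the scatter) in size. Hydroxy does more than give back the gain from methyl, since a 2.9-fold higher number from compound 1 to compound 3 (0.46 log units; beyond the scatter) shows weaker inhibition than with hydrogen at the same place, so methyl and hydroxy move the number in opposite directions from compound 1. No accompanying measurement offers a reason why these two groups, each a single heavy atom, part ways so sharply.

Going by these compounds, what remains open is whether the loss belongs to hydroxy alone or extends to other groups that carry oxygen or nitrogen here, which methoxy or an amine at this same position could help to show. On these data alone, it is also open whether the gain seen with methyl goes further with a longer chain such as ethyl, or whether it also appears with a halogen such as chlorine.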